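Removing a Single Fluorine: Compound 3 to Compound 4

A few compounds are considered here, and "the series" means these few. Any claim that something is new, unique, unknown or untested is made for them only; others in the source may bear on it.

Of the compounds shown here, three built on one shared core have been measured in an assay on Sf9 cells for inhibition of protein deacetylase HDAC6 (Homo sapiens), read by fluorescence, with a stated time of 40 min; on this read-out lower numbers stand for stronger inhibition and higher numbers for weaker inhibition. Compound 1 `COc1ccc(-c2nc(CNc3ccc(C(=O)NO)cc3)n(-c3ccccc3)n2)cc1` gives 163 nM, compound 2 `O=C(NO)c1ccc(NCc2nc(-c3ccccc3)nn2-c2cccc(Cl)c2)cc1` gives 678 nM, and compound 3 `O=C(NO)c1ccc(NCc2nc(-c3ccccc3)nn2-c2ccc(F)cc2)cc1` gives 274 nM. Among these, compound 3 stands second highest of the three numbers; its nearest neighbour is compound 1, whose value lies within the scatter of that of compound 3, while compound 2 lies furthest away, beyond the scatter. Within the data shown here, the only measured step that changes a single place is a 2.5-fold lower number from compound 2 to compound 3 (0.39 log units; beyond the scatter), in which 4-fluorophenyl takes the place of 3-chlorophenyl on an aromatic nitrogen.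

Compound 4 `O=C(NO)c1ccc(NCc2nc(-c3ccccc3)nn2-c2ccccc2)cc1` is compound 3 with one atom taken away: hydrogen in place of fluoro on an aromatic carbon. Among the measured compounds shown here, no measured pair shows this exact change, so the step from compound 2 to compound 3 is the only guide, and it concerns a different group on the same ring. Compound 1 also carries a plain phenyl on that aromatic nitrogen, but it differs from compound 4 elsewhere too, so its value shows only that such a phenyl falls within the range already seen. The expected step is a 1.1-fold lower number from compound 3 to compound 4 (0.04 log units; within the scatter), not clearly beyond the scatter in either direction. Compound 4 is therefore estimated at 250 nM, with a range from 110 nM to 560 nM.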

Compound 4, half-maximal inhibitory concentration: 112 nM
For compound 4 the middle estimate is 2.2-fold (0.35 log units) above the measured one, and the stated range covers the measured number.
By their numbers in this assay, from the lowest: compounds 4, 1 and 3 (each within the scatter of the next, the first and the last beyond it); then compound 2.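

In this assay, among these compounds, taking the fluoro off the 4-fluorophenyl group gives a 2.4-fold lower number from compound 3 to compound 4 (0.39 log units; beyond the scatter), which shows that even this single atom matters at this position, and this is the first direct comparison of a substituted ring there with a plain phenyl. Taking the chloro off the 3-chlorophenyl group gives a 6.1-fold lower number from compound 2 to compound 4 (0.78 log units; beyond the scatter), so among these three compounds, each of the two halogen-bearing rings has a higher number than the plain phenyl, by a margin beyond the scatter. At a different place on the shared core, hydrogen in place of methoxy gives a 1.5-fold lower number from compound 1 to compound 4 (0.16 log units; within the scatter), so that change shows no clear effect on this read-out.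

No measurement at hand offers a reason for the effect of fluoro or chloro at this position. As far as these compounds go, the chloro and fluoro compounds differ in both the halogen and its place on the ring, so it remains open which of the two counts, and also how this ring would respond to a methyl, an amine or a carboxylic acid.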